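The compounds below may be only part of what the source reports. "The series", "measured", "known", "first", "only" and "open" are said of these compounds alone.

Measured compounds:

Compound 1, `O=S(=O)(/C=C/c1ccc(O)c(O)c1)NCc1ccc(C(F)(F)F)cc1`: 2.8 10^-6 cm/s
Compound 2, `O=S(=O)(/C=C/c1ccc(O)c(O)c1)NCc1ccc(F)cc1`: 6 10^-6 cm/s
Compound 3, `CC(=O)Oc1ccc(/C=C/S(=O)(=O)NCc2ccc(C(F)(F)F)cc2)cc1OC(C)=O`: "nd(insoluble)" (no result reported)

All three were run in an ADME assay for permeability, using PAMPA, with a stated time of 18 h, tested at 25 ug/mL; on this read-out higher numbers stand for higher permeability and lower numbers for lower permeability. Compound 1 gives 2.8 10^-6 cm/s, and compound 2 gives 6 10^-6 cm/s. Compound 3 returned only "nd(insoluble)" (no result reported), so no number is available for it in this assay.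

Compound 1 and compound 2 share one core and differ in a single spot: fluoro in place of trifluoromethyl on an aromatic carbon. That change produced a 2.1-fold higher number from compound 1 to compound 2 (0.33 log units; beyond the scatter), a step that is small but larger than the usual run-to-run noise of this kind of measurement.

Compound 4, `CC(=O)Oc1ccc(/C=C/S(=O)(=O)NCc2ccc(F)cc2)cc1OC(C)=O`, has not been measured yet. It is related to compound 3 in exactly the way compound 2 is related to compound 1: fluoro in place of trifluoromethyl on an aromatic carbon. The change sits in the same surroundings in both pairs, so it is the same change made on a different core. How the core of compound 3 differs from the core of compound 1 is not broken down here.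

Going by the values given here, with only one measured example of this change, the expectation for compound 4 in this assay rests on that single pair: a step of about the size seen from compound 1 to compound 2, that is a 2.1-fold higher number from compound 1 to compound 2 (0.33 log units; beyond the scatter), is expected, though compound 3 gave no number, so there is no fixed starting point. Compound 4 is therefore estimated at about 8 10^-6 cm/s, expected to lie between 3 10^-6 cm/s and 20 10^-6 cm/s, with a real chance that it too yields no number.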

Compound 4, apparent permeability: 7.5 10^-6 cm/s
Beside the measured number, compound 4's estimate is 1.1-fold (0.03 log units) above it, and the stated range covers the measured number.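

Going by these compounds alone, compound 3 gave only "nd(insoluble)" (no result reported) in this assay, while compound 4 gives 7.5 10^-6 cm/s, so no step from compound 3 to compound 4 can be read. The compounds shown leave open whether trifluoromethyl to fluoro on this core matches the change seen on the other core, where the result was a 2.1-fold higher number from compound 1 to compound 2 (0.33 log units; beyond the scatter). Nothing given here explains the value of compound 4.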